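The source may hold more compounds than are shown below. What is called first, only, known or untested is meant among the compounds shown, and "the series" means these compounds.

The measured compounds in a functional assay on SGC-7901 cells (Homo sapiens) for inhibition, read by MTT assay, with a stated time of 72 h; on this read-out higher numbers stand for weaker inhibition of growth and lower numbers for stronger inhibition of growth:
Compound 1 `COC1=C(OC)C(=O)C(CCCCCCn2cc(C[C@H](O)COCCOC[C@@H](O)Cc3ccc(-c4ccccc4)cc3)nn2)=C(C)C1=O` gives 16700 nM.
Compound 3 `COC1=C(OC)C(=O)C(CCCCCCCCCCCCCCCn2cc(C[C@H](O)COCCOC[C@@H](O)Cc3ccc(-c4ccccc4)cc3)nn2)=C(C)C1=O` gives 2490 nM.
Compound 2 `O[C@H](COCCOC[C@@H](O)Cc1cn(-c2cncnc2)nn1)Cc1ccc(-c2ccccc2)cc1` reaches only > 100000 nM, which is a limit of this assay and not a number.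

Compound 2 therefore stands at the limit of > 100000 nM in this assay, at which 1 of the 3 values shown sits, the weakest end of what this assay can report. Compound 4 `N#Cc1ccc(Cn2cc(C[C@H](O)COCCOC[C@@H](O)Cc3ccc(-c4ccccc4)cc3)nn2)cc1` differs from it by 4-cyanobenzyl in place of pyrimidin-5-yl on an aromatic nitrogen, in words 4-cyanobenzyl in place of pyrimidin-5-yl on an aromatic nitrogen. For the measured compounds named here, no measured pair shows this exact change, so the expected step in this assay rests on the whole set: compounds 1 and 3, which carry larger groups on that same nitrogen, give numbers rather than a limit. Compound 4 is expected to gain modestly, by a step of an at least 1.6-fold lower number from compound 2 to compound 4 (0.22 log units; that floor lies within the scatter). Compound 4 is estimated at 60000 nM, within 20000 nM to 150000 nM.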

Compound 4, concentration for 50% growth inhibition: 7700 nM
Compound 4: middle estimate off by 7.8-fold (0.89 log units), on the high side; the whole stated range lies above it.
By their numbers in this assay, from the lowest: compound 3; then compound 4; then compound 1. At a limit, above all of these: compound 2.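

In this assay, 4-cyanobenzyl in place of pyrimidin-5-yl on this aromatic nitrogen gives an at least 12-fold lower number from compound 2 to compound 4 (1.11 log units; beyond the scatter), a large step. A measurable value at this position therefore does not require the much larger groups of compound 1 and compound 3: a benzyl group bearing a nitrile is enough. The value of compound 2 is a limit of the assay and not a number: the limit of > 100000 nM in this assay, at which 1 of the 4 values shown sits.

Going by these compounds, what remains open is whether the nitrile or the benzyl part carries this gain. A plain benzyl group or a 4-carboxybenzyl group on the same nitrogen would help separate the two.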